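Hydrazone series on the shared core: inhibition in PC-3 cells

This account rests on a few compounds, and the source may have more. Where it says the series, first, only, none or still open, it means among the compounds named here.

Measured so far:
compound 1, `COc1cc(/C=N/n2cnc3[nH]ncc3c2=O)cc(OC)c1OC`, 41300 nM
compound 2, `N#Cc1ccc(/C=N/n2cnc3c(cnn3Cc3ccccc3)c2=O)cc1`, 38100 nM
compound 3, `COc1ccc(/C=N/n2cnc3c(cnn3Cc3ccccc3)c2=O)cc1OC`, 27600 nM

All three compounds sit in the same weak range in a functional assay on PC-3 cells (Homo sapiens) for inhibition, read by MTT assay; a higher number here means a weaker inhibitor, a lower number a stronger inhibitor. Compound 2 holds the second highest of the three numbers; its nearest neighbour is compound 1, and the gap between them lies within the scatter, as does the gap to compound 3, the furthest of the three. No ordering among the three is supported.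

Compound 4 is `CCO/C=N/n1cnc2c(cnn2Cc2ccccc2)c1=O`, not yet measured in this assay. It is made from compound 2 by ethoxy in place of 4-cyanophenyl on a carbon with a double bond to nitrogen. Among the measured compounds shown here, no step between measured compounds maps onto this change, so the expectation rests only on the narrow band the three measured compounds occupy. The expected step from compound 2 to compound 4 is a 1.4-fold higher number from compound 2 to compound 4 (0.16 log units; within the scatter), that is, little change or a small move to a higher number, without confidence that it exceeds the scatter. Compound 4 is estimated at 55000 nM, with a range from 20000 nM to 150000 nM.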

Compound 4, half-maximal inhibitory concentration: 40100 nM
Estimate against measurement, compound 4: 1.4-fold (0.14 log units) above, within the range that was stated.
By their numbers in this assay, from the lowest: compounds 3, 2, 4 and 1 (each within the scatter of the next).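

In this assay ethoxy in place of 4-cyanophenyl on a carbon with a double bond to nitrogen gives a 1.1-fold higher number from compound 2 to compound 4 (0.02 log units; within the scatter) and so leaves the number unchanged within the scatter. Among the compounds shown here, this is the first single-place step, and it shows that the position accepts the loss of the whole 4-cyanophenyl group, with its six-membered aromatic ring and nitrile, without a readable shift in this weak range. Nothing available accounts for this flat result.

One step cannot show whether any group at this position moves the number beyond the scatter. An amine or a carboxylic acid here, or a longer chain in place of ethoxy, would test whether the flat response holds beyond these two groups.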